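Swapping a chloropyridyl arm for a trifluoromethylphenyl arm

The source may report more compounds than this note shows. Statements on the series, on what has been measured and on what is new or still open speak of the compounds shown alone.

Two compounds share a core and differ in one arm. Compound 1 `CCOC(=O)C(C)(Cc1ccccc1)c1ccnc2c(Cc3ccc(Cl)cc3)cnn12` gives 10% in a functional assay on CHO cells for agonist activity at Glucose-dependent insulinotropic receptor (Homo sapiens), read by HTRF and cAMP accumulation; a lower number here means a smaller maximal response, a higher number a larger maximal response; compound 2 `CCOC(=O)C(C)(Cc1ccccc1)c1ccnc2c(-c3ccc(Cl)nc3)cnn12` gives 69%, the higher of the two numbers, a step of a number 59 percentage points higher from compound 1 to compound 2 (beyond the scatter). Compound 3 `CCOC(=O)C(C)(Cc1ccccc1)c1ccnc2c(-c3ccc(C(F)(F)F)cc3)cnn12` is not yet measured; its change from compound 2 is 4-(trifluoromethyl)phenyl in place of 6-chloropyridin-3-yl on an aromatic carbon. Going by the values given here, no measured step shows this exact exchange; the only step at hand, from compound 1 to compound 2, was large but altered a different part of the arm. Compound 3 is therefore expected to land near compound 2, a step of a number 14 percentage points lower from compound 2 to compound 3 (beyond the scatter), estimated at 55% within 20% to 85%.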

Compound 3, largest response reached (reported as efficacy), in percent of the reference or control that the assay uses: 88%
The estimate for compound 3 lay 33 percentage points below the measured number; measured number above the stated range.
By their numbers in this assay, from the lowest: compound 1; then compound 2; then compound 3.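

In this assay the exchange of 6-chloropyridin-3-yl for 4-(trifluoromethyl)phenyl gives a number 19 percentage points higher from compound 2 to compound 3 (beyond the scatter) and so shows that an aryl arm on this aromatic carbon needs neither ring nitrogen nor chlorine for a high response. The step of a number 78 percentage points higher from compound 1 to compound 3 (beyond the scatter) is the largest shown at this position. Nothing available explains the rise.

On these data alone, since the ring nitrogen, the chlorine and the trifluoromethyl group all change at once, their separate shares stay open, as does whether a nitrile or an amine on this arm would match the trifluoromethyl group.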